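From benzyl to 2-cyclopentylethyl on the shared core

The compounds below may be only part of what the source reports. "The series", "measured", "known", "first", "only" and "open" are said of these compounds alone.

Compound 1 `CC(C)(C)CCOc1cccc(O)c1C(=O)/C=C/c1ccc(O)cc1` gives 2380 nM
Compound 2 `O=C(/C=C/c1ccc(O)cc1)c1c(O)cccc1OCC1CCCC1` gives 3410 nM
Compound 3 `O=C(/C=C/c1ccc(O)cc1)c1c(O)cccc1OCc1ccccc1` gives > 30000 nM (a limit, not a number)

These three compounds were tested in a functional assay on MDA-MB-231 cells (Homo sapiens) for antiproliferative activity, read by sulforhodamine B assay (on this read-out higher numbers stand for weaker inhibition of growth and lower numbers for stronger inhibition of growth), and differ only in one group on the shared core. Compound 3 is the weakest of the three, and its entry is only a limit (the limit of > 30000 nM in this assay, at which 1 of the 3 values shown sits).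

Compound 4 `O=C(/C=C/c1ccc(O)cc1)c1c(O)cccc1OCCC1CCCC1` keeps the core but swaps benzyl for 2-cyclopentylethyl (cyclopentylmethyl in place of phenyl on a saturated chain carbon bound to an oxygen on an aromatic ring). Going by the values given here, two measured steps bear most directly on this change. Phenyl in place of neopentyl gave a large rise in the number (an at least 12-fold higher number from compound 1 to compound 3 (1.10 log units; beyond the scatter)), and phenyl in place of cyclopentyl also raised it (an at least 8.7-fold higher number from compound 2 to compound 3 (0.94 log units; beyond the scatter)). The two saturated groups themselves stay within the scatter of each other (a 1.4-fold higher number from compound 1 to compound 2 (0.16 log units; within the scatter)).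

Compound 4 loses the phenyl and carries a cyclopentyl group, as compound 2 (3410 nM) does, so a value near those of the saturated compounds is expected. The number is therefore expected to fall clearly, which would mean stronger inhibition of growth (an at least 10-fold lower number from compound 3 to compound 4 (1.00 log units; beyond the scatter)). The estimate for compound 4 is 3000 nM (range 1200 nM to 8000 nM).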

Compound 4, concentration for 50% growth inhibition: 3340 nM
Compound 4: the middle estimate sits 1.1-fold (0.05 log units) below what was measured, and the stated range covers the measured number.
By their numbers in this assay, from the lowest: compounds 1, 4 and 2 (each within the scatter of the next). At a limit, above all of these: compound 3.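

Compound 3 counts only as a limit, not as a number: the limit of > 30000 nM in this assay, at which 1 of the 4 values shown sits. The group that leaves and the group that enters have the same count of heavy atoms, yet the 2-cyclopentylethyl side chain of compound 4 gives clearly stronger inhibition of growth than the benzyl side chain (an at least 8.9-fold lower number from compound 3 to compound 4 (0.95 log units; beyond the scatter)). The scatter does not separate 2-cyclopentylethyl from cyclopentylmethyl (a 1.0-fold lower number from compound 2 to compound 4 (0.01 log units; within the scatter)) or from the neopentyl-bearing chain (a 1.4-fold higher number from compound 1 to compound 4 (0.15 log units; within the scatter)), so among these four compounds the three with saturated groups sit together and only the benzyl compound stands apart.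

As far as these compounds go, whether 2-phenylethyl would behave like benzyl or like the saturated groups stays open. Also open, from the compounds shown here alone, is how a longer chain ending in cyclopentyl, or an amine or a carboxylic acid on the chain, would fare.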